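The compounds below may be only part of what the source reports. "The series", "measured", "known", "first", "only" and "open" are said of these compounds alone.

Of the compounds shown here, three that share a common core have been measured in a functional assay on isolated protein for inhibition of Glucose-dependent insulinotropic receptor (Rattus norvegicus), read by HTRF and cAMP accumulation; a higher number here means a larger maximal response, a lower number a smaller maximal response. Compound 1 `Cc1nc(S(C)(=O)=O)ccc1Oc1ncnc(OC2CCN(C(=O)OC(C)(C)C#N)CC2)c1F` gives 97% in this assay. Compound 2 `Cc1nc(S(C)(=O)=O)ccc1Oc1ncnc(OC2CCN(C(=O)OC3(C(F)(F)F)COC3)CC2)c1F`, which carries 3-(trifluoromethyl)oxetan-3-yl in place of 1-cyano-1-methylethyl on an oxygen next to a carbonyl group, gives 84%, a step of a number 13 percentage points lower from compound 1 to compound 2 (beyond the scatter). Compound 3 `Cc1nc(S(C)(=O)=O)ccc1Oc1ncnc(OC2CCN(C(=O)SC(C)C)CC2)c1F`, with isopropylsulfanyl on the carbonyl carbon, gives 81%. Going by the values given here, its number is the lowest of the three, but only the step of a number 16 percentage points lower from compound 1 to compound 3 (beyond the scatter) lies beyond the scatter, while the step of a number 3 percentage points lower from compound 2 to compound 3 (within the scatter) lies within it, so compound 3 and compound 2 cannot be told apart.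

Compound 4 `Cc1nc(S(C)(=O)=O)ccc1Oc1ncnc(OC2CCN(C(=O)C(F)(F)F)CC2)c1F` has not yet been measured. It differs from compound 3 at the carbonyl carbon: trifluoromethyl in place of isopropylsulfanyl on a carbonyl carbon. The measured steps that bear on this change are the two earlier swaps at the carbonyl carbon, a number 16 percentage points lower from compound 1 to compound 3 (beyond the scatter) and a number 3 percentage points lower from compound 2 to compound 3 (within the scatter), one modest and one within the scatter. Such swaps have moved the maximal response only a little, so in this assay a step of about a number 1 percentage points lower from compound 3 to compound 4 (within the scatter) is expected, which means no change beyond the scatter. Compound 4 is therefore estimated to give 80%, with a range from 62% to 96%.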

Compound 4, largest response reached (reported as efficacy), in percent of the reference or control that the assay uses: 76%
Compound 4: middle estimate off by 4 percentage points, on the high side, within the range that was stated.
By their numbers in this assay, from the lowest: compounds 4, 3 and 2 (each within the scatter of the next); then compound 1.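

The new compound shows that the carbonyl carbon tolerates a group with no oxygen or sulfur linking it to the carbonyl: in this assay, trifluoromethyl in place of isopropylsulfanyl gives a number 5 percentage points lower from compound 3 to compound 4 (within the scatter), and in place of (3-(trifluoromethyl)oxetan-3-yl)oxy it gives a number 8 percentage points lower from compound 2 to compound 4 (within the scatter), so compound 4 cannot be told apart from compound 3 or compound 2. Going by these compounds alone, the remaining step, a number 21 percentage points lower from compound 1 to compound 4 (beyond the scatter), is the largest seen at this position so far, and it leaves 1-cyano-1-methylethoxy as the only one of the four groups whose compound is separated from all the others by more than the scatter. Nothing available explains why the maximal response of compound 1 stands apart from the other three.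

The compounds shown leave open what a group joined through nitrogen, such as an amine like dimethylamino, would do on this carbonyl carbon. They also leave open whether a plain carbon group, such as methyl or a longer alkyl chain, would match trifluoromethyl or whether the fluorine atoms matter for the response.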